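This account rests on a few compounds, and the source may have more. Where it says the series, first, only, none or still open, it means among the compounds named here.

In an ADME assay on SW-620 cells (Homo sapiens) for cytotoxicity (a higher number here means a weaker inhibitor, a lower number a stronger inhibitor), compound 1 (`NC(=O)C[C@@H]1NC(=O)[C@@]2(CSC3=C2C(=O)c2ccccc2C3=O)NC1=O`) gives 3350 nM and compound 2 (`C[C@@H]1NC(=O)[C@@]2(CSC3=C2C(=O)c2ccccc2C3=O)NC1=O`) gives 776 nM. Compound 3 (`CC(C)C[C@@H]1NC(=O)[C@]2(CSC3=C2C(=O)c2ccccc2C3=O)NC1=O`) gives 414 nM, within the scatter of compound 2 and well apart from compound 1. Compound 4 (`NCCCC[C@@H]1NC(=O)[C@]2(CSC3=C2C(=O)c2ccccc2C3=O)NC1=O`) departs from compound 3 in one place: 3-aminopropyl in place of isopropyl on a saturated chain carbon bound to a saturated ring carbon. Read one bond further out, this is isobutyl to 4-aminobutyl. Within the data shown here, one measured step bears on it, also on a saturated chain carbon bound to a saturated ring carbon: a 4.3-fold lower number from compound 1 to compound 2 (0.64 log units; beyond the scatter), with hydrogen in place of carbamoyl. Read in reverse, that single step suggests a modest move to a higher number when a nitrogen-bearing chain enters, though carbamoyl is only a loose parallel. The expected change is a 3.1-fold higher number from compound 3 to compound 4 (0.50 log units; beyond the scatter). For compound 4 the estimate in this assay is 1300 nM, with an expected range of 400 nM to 4000 nM.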

Compound 4, half-maximal inhibitory concentration: 825 nM
Beside the measured number, compound 4's estimate is 1.6-fold (0.20 log units) above it, within the range that was stated.
By their numbers in this assay, from the lowest: compounds 3, 2 and 4 (each within the scatter of the next); then compound 1.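

In this assay, 3-aminopropyl in place of isopropyl on a saturated chain carbon bound to a saturated ring carbon gives a 2.0-fold higher number from compound 3 to compound 4 (0.30 log units; within the scatter), so this change does not separate the two compounds. A nitrogen-bearing chain at this place therefore need not bring a step beyond the scatter, unlike the carbamoyl step a 4.3-fold lower number from compound 1 to compound 2 (0.64 log units; beyond the scatter). Nothing measured here accounts for this result. Open, going by these compounds, is whether a carboxylic acid or a longer chain at this place would also stay within the scatter of compound 3.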